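The source may hold more compounds than are shown below. What is called first, only, known or untested is meant among the compounds shown, and "the series" means these compounds.

Compound 1 `CCC(C)n1cnc2c(NCc3ccc(C(=O)Nc4ccccc4N)cc3)nc(Cl)nc21` holds the higher of the two measured numbers: in a functional assay on NCI-H460 cells (Homo sapiens) for antiproliferative activity, read by CCK-8 assay, with a stated time of 72 h, tested at 8 uM (a higher number here means a stronger effect of the compound at the concentration tested, a lower number a weaker effect), compound 1 gives 67.7%, while compound 2 `Nc1ccccc1NC(=O)c1ccc(Cn2cnc3c(Nc4ccc(-c5ccccn5)cc4)nc(Cl)nc32)cc1` gives 30.8% in the same test, a gap beyond the usual scatter. Compound 3 `CCCn1cnc2c(NCc3ccc(C(=O)Nc4ccccc4N)cc3)nc(Cl)nc21` has not been measured yet. It differs from compound 1 by one change only: hydrogen in place of methyl on a saturated chain carbon bound to an aromatic nitrogen and a saturated chain carbon. Among the compounds with values here, no measured pair shows this exact change, so only a small step is expected, most likely within the scatter, if anything slightly downward. Compound 3 is therefore estimated at 60%, with a likely range from 42% to 76%. The expected step is a number 7.7 percentage points lower from compound 1 to compound 3 (within the scatter).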

Compound 3, a percentage reported as inhibition, at one concentration (the size of the read-out at that concentration, not a potency): 39.2%
Estimate against measurement, compound 3: 20.8 percentage points above; the whole stated range lies above it.
By their numbers in this assay, from the lowest: compounds 2 and 3 (each within the scatter of the next); then compound 1.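

Removing one methyl at this place, so that sec-butyl becomes propyl, gives in this assay a number 28.5 percentage points lower from compound 1 to compound 3 (beyond the scatter) and shows that the saturated chain carbon bound to an aromatic nitrogen is sensitive to even this small change. With the rest of the molecule unchanged, this single methyl accounts for the whole step. Nothing available explains why the number falls. The compounds shown leave open whether the branch itself or the size of the chain matters. Isopropyl, cyclopentyl or a longer chain such as butyl at this place could begin to separate the two.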